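The source may report more compounds than this note shows. Statements on the series, on what has been measured and on what is new or still open speak of the compounds shown alone.

Within the data shown here, in a functional assay on SNB-75 cells (Homo sapiens) for inhibition, read by sulforhodamine B assay, with a stated time of 48 h, tested at 0.01 uM (a higher number here means a weaker effect of the compound at the concentration tested, a lower number a stronger effect), compound 3 `COc1cc(Cl)cc(-c2nn(-c3cccc(NC(=O)Nc4cccc(C(F)(F)F)c4)c3)cc2-c2ccncc2)c1` gives 83%, the second highest of the three numbers measured so far. Compound 2 `COc1cc(Cl)cc(-c2nn(-c3cccc(NC(=O)Nc4ccc(Cl)c(Cl)c4)c3)cc2-c2ccncc2)c1` gives 88% in this assay, and compound 1 `COc1cc(Cl)cc(-c2nn(-c3cccc(NC(=O)Nc4ccc(Cl)c(C(F)(F)F)c4)c3)cc2-c2ccncc2)c1` gives 57%. The step of a number 5 percentage points lower from compound 2 to compound 3 (within the scatter) lies within the scatter, whereas a number 26 percentage points higher from compound 1 to compound 3 (beyond the scatter) and a number 31 percentage points higher from compound 1 to compound 2 (beyond the scatter) lie beyond it. Compound 4 `COc1cc(Cl)cc(-c2nn(-c3cccc(NC(=O)c4cccc(C(F)(F)F)c4)c3)cc2-c2ccncc2)c1` differs from compound 3 by 3-(trifluoromethyl)phenyl in place of (3-(trifluoromethyl)phenyl)amino on a carbonyl carbon. Among the measured compounds shown here, every measured step exchanges chloro, trifluoromethyl or hydrogen on an aromatic carbon, and none changes the amide-type nitrogen or the carbonyl carbon, so no measured step bears directly on this change. For compound 4 a step of a number 2 percentage points higher from compound 3 to compound 4 (within the scatter) in this assay is expected, within the scatter. Compound 4 is therefore estimated at 85%, between 60% and 100%.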

Compound 4, a percentage reported as activity, at one concentration (the size of the read-out at that concentration, not a potency): 90%
For compound 4 the middle estimate is 5 percentage points below the measured one; the range from low to high includes it.
By their numbers in this assay, from the lowest: compound 1; then compounds 3, 2 and 4 (each within the scatter of the next).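

Removing the amino nitrogen, and with it a hydrogen-bond donor, from the group on the carbonyl carbon leaves the read-out in this assay unchanged, with a number 7 percentage points higher from compound 3 to compound 4 (within the scatter), and a number 2 percentage points higher from compound 2 to compound 4 (within the scatter) likewise shows no separation. Only compound 1 stands apart, at a number 33 percentage points higher from compound 1 to compound 4 (beyond the scatter), but that step also removes chloro, so it does not isolate the nitrogen. No measurement here explains these results. Open, going by these compounds, is whether a methylene or an oxygen in place of the amino nitrogen would read alike, and whether 4-chloro-3-(trifluoromethyl)phenyl directly on the carbonyl carbon would keep the stronger effect of compound 1.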